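Aryl caps on the aminoethyl linker: amide against sulfonyl

This account rests on a few compounds, and the source may have more. Where it says the series, first, only, none or still open, it means among the compounds named here.

Measured so far:
Compound 1 `O=S(=O)(NCCNc1nccc(-c2c(-c3cccc(F)c3)nc3sccn23)n1)c1ccc(Br)cc1` gives 13500 nM in a functional assay on A-375 cells (Homo sapiens) for cytotoxicity, read by MTT assay; a higher number here means a weaker inhibitor, a lower number a stronger inhibitor.
Compound 2 `O=C(NCCNc1nccc(-c2c(-c3cccc(F)c3)nc3sccn23)n1)c1c(F)cccc1F` gives 2700 nM in this assay.
Compound 3 `O=S(=O)(NCCNc1nccc(-c2c(-c3cccc(F)c3)nc3sccn23)n1)c1ccccc1` gives 11000 nM in this assay.

Compound 2 holds the lowest number of the three. The step of a 5.0-fold lower number from compound 1 to compound 2 (0.70 log units; beyond the scatter) and the step of a 4.1-fold higher number from compound 2 to compound 3 (0.61 log units; beyond the scatter) both lie beyond the scatter, so the amide cap of compound 2 stands apart from the two sulfonyl caps. The step of a 1.2-fold lower number from compound 1 to compound 3 (0.09 log units; within the scatter) lies within the scatter.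

Compound 4 `O=C(NCCNc1nccc(-c2c(-c3cccc(F)c3)nc3sccn23)n1)c1ccccc1` keeps the amide cap of compound 2 and differs from it only in the ring on that cap: phenyl in place of 2,6-difluorophenyl on a carbonyl carbon. The closest measured precedent is the removal of a halogen from the aromatic ring of a cap, a 1.2-fold lower number from compound 1 to compound 3 (0.09 log units; within the scatter), which changed nothing beyond the scatter, though that was on a sulfonyl rather than a carbonyl and concerned a single bromo rather than two fluorines. The amide-against-sulfonyl steps do not bear on ring substitution itself. On this basis the change to compound 4 is expected to give no step beyond the scatter, or at most a small rise; the expected step is a 1.5-fold higher number from compound 2 to compound 4 (0.17 log units; within the scatter). Compound 4 is estimated at 4000 nM, with a range from 1500 nM to 11000 nM.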

Compound 4, half-maximal inhibitory concentration: 5060 nM
Estimate against measurement, compound 4: 1.3-fold (0.10 log units) below; the measured number falls inside the stated range.
By their numbers in this assay, from the lowest: compounds 2 and 4 (each within the scatter of the next); then compounds 3 and 1 (each within the scatter of the next).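

In this assay the amide cap tolerates the loss of both fluorines: the step to phenyl in place of 2,6-difluorophenyl on the carbonyl carbon (a 1.9-fold higher number from compound 2 to compound 4 (0.27 log units; within the scatter)) stays within the scatter, so no effect of these fluorines can be read at this position. Within the data shown here, compound 4 also allows the first comparison of carbonyl against sulfonyl with an unsubstituted ring on both caps (a 2.2-fold lower number from compound 3 to compound 4 (0.34 log units; beyond the scatter)), and the comparison with the bromo-bearing sulfonyl cap points the same way (a 2.7-fold lower number from compound 1 to compound 4 (0.43 log units; beyond the scatter)), so across these four compounds both amides give lower numbers than both sulfonyl compounds, with no compound going against this, and the gap does not rest on the fluorines of compound 2. Nothing available here accounts for the difference between the two cap types.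

The compounds shown leave open whether a single fluorine or a bromo on the benzoyl ring would also stay within the scatter, and whether the carbonyl cap keeps its lower numbers with an alkyl group such as acetyl in place of the aromatic ring. Also open, going by these compounds, is how a cap bearing an amine or a carboxylic acid, or a longer chain in place of the aminoethyl linker, would read in this assay on this core.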